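The source may hold more compounds than are shown below. What is called first, only, known or untested is meant among the compounds shown, and "the series" means these compounds.

Measured compounds in a functional assay on thoracic aorta (Rattus norvegicus, strain Wistar), with a stated time of 15 min; on this read-out higher numbers stand for an effect only at larger amounts of compound and lower numbers for an effect already at smaller amounts:
compound 1 `COc1ccc(Br)cc1C(C)NC(=O)NS(=O)(=O)c1ccc(Cl)cc1` — 80900 nM
compound 2 `CCOc1ccc(Br)cc1C(C)NC(=O)NS(=O)(=O)c1ccccc1` — > 300000 nM, a limit of the assay rather than a number
compound 3 `CC(C)Oc1ccc(Br)cc1C(C)NC(=O)NS(=O)(=O)c1ccc(Cl)cc1` — 122000 nM

Compound 3 holds the highest of the two numbers given in this assay; its nearest neighbour is compound 1, which gives 80900 nM, and that gap is within the scatter. Among the measured compounds shown here, the one measured step, a 1.5-fold higher number from compound 1 to compound 3 (0.18 log units; within the scatter), is likewise within the scatter. For the measured compounds named here, compound 2 sits at the limit of > 300000 nM in this assay, at which 1 of the 3 values shown sits, so its reading is a limit and supplies no measured step.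

The unmeasured compound 4 is `CCOc1ccc(Br)cc1C(C)NC(=O)NS(=O)(=O)c1ccc(Cl)cc1`. It differs from compound 3 by hydrogen in place of methyl on a saturated chain carbon bound to an oxygen on an aromatic ring and a saturated chain carbon. This is a change of the same kind as the measured step, a shorter alkyl on the oxygen on the aromatic ring while the chloro on the sulfonyl ring is kept. Since methyl and isopropyl on that oxygen gave numbers within the scatter of each other, no step beyond the scatter is expected for ethyl either.

Compound 4 is therefore estimated at 100000 nM, with a range from 40000 nM to 250000 nM. The expected step from compound 3 is a 1.2-fold lower number from compound 3 to compound 4 (0.09 log units; within the scatter).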

Compound 4, half-maximal effective concentration: 171000 nM
The estimate for compound 4 lay 1.7-fold (0.23 log units) below the measured number, within the range that was stated.
By their numbers in this assay, from the lowest: compounds 1, 3 and 4 (each within the scatter of the next, the first and the last beyond it). At a limit, above all of these: compound 2.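

In this assay, among the compounds shown here, the ethyl on the oxygen gives the first step beyond the scatter at this position, though a modest one: a 2.1-fold higher number from compound 1 to compound 4 (0.33 log units; beyond the scatter). The isopropoxy to ethoxy change itself stays within the scatter, a 1.4-fold higher number from compound 3 to compound 4 (0.15 log units; within the scatter), so compound 3 cannot be separated from either compound 1 or compound 4, and the three alkyl groups form no resolved order. The series also gains a reading for chloro in place of hydrogen on an aromatic carbon, an at least 1.7-fold lower number from compound 2 to compound 4 (0.24 log units; that floor lies within the scatter), but this step rests on a value that is a limit and not a number: the limit of > 300000 nM in this assay, at which 1 of the 4 values shown sits.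

On these data alone, what a longer chain or a terminal amine on that oxygen would give remains open. Also open, as far as these compounds go, is whether the step from methyl to ethyl holds without the chloro.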